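Selenium-bearing fused bicycles: early cytotoxicity notes

The source may hold more compounds than are shown below. What is called first, only, known or untested is meant among the compounds shown, and "the series" means these compounds.

Measured so far:
- compound 1 `C[Se]c1nc(N)c2ccccc2n1` gives 18000 nM
- compound 2 `[SeH]c1nc([SeH])c2ccccc2n1` gives 5980 nM
- compound 3 `CSc1nc(NCc2ccccc2)c2ccccc2n1` gives 37900 nM

All three numbers come from a functional assay on HTB-54 cells (Homo sapiens) for cytotoxicity, read by MTT assay, with a stated time of 72 h; on this read-out lower numbers stand for stronger inhibition of growth and higher numbers for weaker inhibition of growth. Compound 2 stands lowest of the three; compound 1 lies beyond the scatter above it, and compound 3 lies further above still. Going by the values given here, none of the measured pairs differ in a single place, so no one-point step can be read from them, and only the bare values can be set side by side.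

Compound 4 `Nc1nc([SeH])nc2ccccc12` has not been measured in this assay. It differs from compound 2 by one nitrogen atom in place of one selenium atom, on an aromatic carbon. The outcome of an amino group sitting on this core is only seen in compound 1, which in this assay gives 18000 nM together with a methylselanyl group rather than a selenol. With that single anchor, the step from compound 2 is expected to run toward weaker inhibition, by a 1.7-fold higher number from compound 2 to compound 4 (0.22 log units; within the scatter), somewhat beyond the scatter but short of the gap to compound 1. Compound 4 is therefore estimated at 10000 nM, with a plausible range from 3500 nM to 30000 nM.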

Compound 4, concentration for 50% growth inhibition: 40 nM
Beside the measured number, compound 4's estimate is 250-fold (2.40 log units) above it, and the stated range ends above it.
By their numbers in this assay, from the lowest: compound 4; then compound 2; then compound 1; then compound 3.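

In this assay, the aromatic carbon next to the ring nitrogen proves far more sensitive than the earlier values suggested: amino in place of selenium there gives a 150-fold lower number from compound 2 to compound 4 (2.17 log units; beyond the scatter) and is a large gain rather than the modest loss that compound 1 seemed to imply. The methyl on selenium matters just as much, since hydrogen in its place, with the amino group kept, gives a 450-fold lower number from compound 1 to compound 4 (2.65 log units; beyond the scatter) and shows that compound 1 could not reveal what an amino group does alongside a free selenol. The low number of compound 4 goes together with both features being present. Compound 2 and compound 1 each lack one of them, and each stands a large step toward weaker inhibition of growth. Nothing available here explains the size of either step.

As far as these compounds go, whether the gain is specific to the amino group remains open, as a methylamine, a dimethylamine or a hydroxyl at the same carbon could behave quite differently. From the compounds shown here alone, it is equally open whether the selenium itself is needed, which a thiol in place of the selenol on compound 4 would address.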